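Swapping a Small Furan for a Fused Benzofuran

The source may report more compounds than this note shows. Statements on the series, on what has been measured and on what is new or still open speak of the compounds shown alone.

Measured so far:
compound 1 `O=c1[nH]cnc2c1c(-c1ccoc1)cn2[C@@H]1O[C@H](CO)[C@@H](O)[C@H]1O` gives 10300 nM
compound 2 `CNc1ncnc2c1c(I)cn2[C@@H]1O[C@H](CO)[C@@H](O)[C@H]1O` reports only a limit, > 100000 nM
compound 3 `Nc1nc2c(c(-c3ccoc3)cn2[C@@H]2O[C@H](CO)[C@@H](O)[C@H]2O)c(=O)[nH]1` gives 14200 nM

In a functional assay on HCT-116 cells (Homo sapiens), read by MTT assay, with a stated time of 72 h (on this read-out lower numbers stand for stronger inhibition and higher numbers for weaker inhibition), compound 1 holds the lowest of the two numbers shown. Its nearest neighbour is compound 3, and a 1.4-fold higher number from compound 1 to compound 3 (0.14 log units; within the scatter) lies within the scatter, so the two cannot be ranked. Compound 2 sits at the limit of > 100000 nM in this assay, at which 1 of the 3 values shown sits, and offers no number.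

Compound 4 `O=c1[nH]cnc2c1c(-c1cc3ccccc3o1)cn2[C@@H]1O[C@H](CO)[C@@H](O)[C@H]1O` differs from compound 1 by 1-benzofuran-2-yl in place of furan-3-yl on an aromatic carbon. Going by the values given here, the only measured step alters a different part of the core, so no measured step bears on this change, and neither its size nor its direction can be read from the data. Compound 4 is therefore expected to stay close to compound 1, a 1.2-fold higher number from compound 1 to compound 4 (0.07 log units; within the scatter), with an estimate of 12000 nM and a range from 3000 nM to 50000 nM.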

Compound 4, half-maximal inhibitory concentration: > 20000 nM
Compound 4: a limit, no number; the forecaster's own chance of this, stated with the estimate: 15%; at least 1.6-fold (0.22 log units) between middle value and limit.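

Compound 4 is reported only as a limit: the limit of > 20000 nM in this assay, at which 1 of the 4 values shown sits. Putting 1-benzofuran-2-yl in place of furan-3-yl gives an at least 1.9-fold higher number from compound 1 to compound 4 (0.28 log units; that floor lies within the scatter). Going by these compounds alone, this is the first look at a change to the group on this aromatic carbon: the fused group shows no gain in inhibition over furan-3-yl, but the true size of the step cannot be read from a limit.

Going by these compounds, it remains open how an amine or a carboxylic acid on this aromatic carbon would compare with furan-3-yl. Also open, on these data alone, is whether 1-benzofuran-2-yl would behave the same way on the core of compound 3.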